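Iodo in place of chloro on the 3-chlorophenyl group

The source may hold more compounds than are shown below. What is called first, only, known or untested is meant among the compounds shown, and "the series" means these compounds.

Of the compounds shown here, three sharing one core have been measured in a functional assay on A549 cells (Homo sapiens) for antiproliferative activity, read by MTT assay, with a stated time of 72 h; a lower number here means a stronger inhibitor, a higher number a weaker inhibitor: compound 1 (`COc1cc2ncnc(Nc3cccc(Br)c3)c2cc1OCCCN1CCNCCNCCNCC1`), compound 2 (`COc1cc2ncnc(Nc3ccc(Cl)c(C(F)(F)F)c3)c2cc1OCCCN1CCNCCNCCNCC1`) and compound 3 (`COc1cc2ncnc(Nc3cccc(Cl)c3)c2cc1OCCCN1CCNCCNCCNCC1`). Compound 3 gives 27100 nM and compound 1 gives 14700 nM, two values within the scatter of each other. Compound 2 gives 5350 nM, and the gap a 5.1-fold higher number from compound 2 to compound 3 (0.70 log units; beyond the scatter) lies beyond the scatter.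

Compound 4 (`COc1cc2ncnc(Nc3cccc(I)c3)c2cc1OCCCN1CCNCCNCCNCC1`) carries the change iodo in place of chloro on an aromatic carbon, meta to a large group. The closest measured precedent is the halogen exchange a 1.8-fold higher number from compound 1 to compound 3 (0.27 log units; within the scatter), which stays within the scatter. The step of a 2.7-fold lower number from compound 1 to compound 2 (0.44 log units; beyond the scatter) replaces the whole aryl group, so it bears only loosely on this change, as does the gap above. Going by the values given here, no iodo compound has been measured yet, so only a small step towards a lower number is expected, probably not beyond the scatter. The expected step is a 1.9-fold lower number from compound 3 to compound 4 (0.29 log units; within the scatter). Compound 4 is estimated at 14000 nM, with an expected range of 6500 nM to 28000 nM.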

Compound 4, half-maximal inhibitory concentration: 14500 nM
For compound 4 the middle estimate is 1.0-fold (0.02 log units) below the measured one, and the stated range covers the measured number.
By their numbers in this assay, from the lowest: compound 2; then compounds 4, 1 and 3 (each within the scatter of the next).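

In this assay, this aromatic carbon, meta to a large group, now carries chloro, bromo and iodo, and both a 1.9-fold lower number from compound 3 to compound 4 (0.27 log units; within the scatter) and a 1.0-fold lower number from compound 1 to compound 4 (0.01 log units; within the scatter) stay within the scatter, so exchanging one halogen here does not separate compound 1, compound 3 and compound 4. Iodo also does not close the gap to the aryl group of compound 2, with a 2.7-fold higher number from compound 2 to compound 4 (0.43 log units; beyond the scatter), and compound 2 remains beyond the scatter of all three single-halogen compounds. No measurement at hand accounts for any of these steps.

Open is whether the lower number of compound 2 follows the chloro or the trifluoromethyl group, as the compounds shown change both together. Also open, from the compounds shown here alone, is whether fluoro, a nitrile or an amine at this aromatic carbon would stay within the scatter of compound 4.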